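Does Fixing the Double Bond Shift Compound 2?

The source may report more compounds than this note shows. Statements on the series, on what has been measured and on what is new or still open speak of the compounds shown alone.

In a functional assay on U-87MG ATCC cells (Homo sapiens) for cytotoxicity, read by MTT assay, with a stated time of 48 h (a higher number here means a weaker inhibitor, a lower number a stronger inhibitor), compound 1 `C/C(=N/NC(=S)Nc1ccccc1)c1ccccn1` gives 1.4 nM and compound 3 `CC(=NNC(=S)Nc1ccccc1)c1ccccn1` gives 1.4 nM as well. Compound 2 `CC(=NNC(=S)Nc1ccccc1[N+](=O)[O-])c1ccccn1` at 4.3 nM is the highest of the three. Compound 4 `C/C(=N/NC(=S)Nc1ccccc1[N+](=O)[O-])c1ccccn1` is the same molecule as compound 2 in atoms and bonds (the two compounds have the same atoms and bonds; at least one stereo element is drawn with a configuration in one of them and without one in the other: 1 of 1 stereo elements differ; a double bond is drawn without a configuration in compound 2 and Z in compound 4): a double bond is drawn without a configuration in compound 2 and Z in compound 4. For the measured compounds named here, the one measured step of this kind is no change at the digits printed from compound 1 to compound 3 (within the scatter) with the fact that one of compounds 1 and 3 is drawn with a defined configuration and the other without, at the place where they differ being the sole difference. The step of a 3.1-fold lower number from compound 2 to compound 3 (0.49 log units; beyond the scatter) is another kind of change, hydrogen in place of nitro, and does not bear on this one. No shift beyond the scatter is therefore expected, and the estimated step is no change at the digits printed from compound 2 to compound 4 (within the scatter) in size. Compound 4 is estimated at 4.3 nM (range 2 nM to 9 nM).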

Compound 4, half-maximal inhibitory concentration: 4.3 nM
The estimate for compound 4 equals the measured number at the digits printed, within the range that was stated.
By their numbers in this assay, from the lowest: compounds 1 and 3 (each within the scatter of the next); then compounds 2 and 4 (each within the scatter of the next).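

In this assay, the double bond drawn Z makes no difference with nitro on the aromatic ring either, no change at the digits printed from compound 2 to compound 4 (within the scatter), so the earlier finding is not limited to the compounds without nitro: the fact that one of compounds 2 and 4 is drawn with a defined configuration and the other without, at the place where they differ. Nitro in place of hydrogen also gives a 3.1-fold higher number from compound 1 to compound 4 (0.49 log units; beyond the scatter), so the nitro step is the same size whether or not a configuration is drawn: the same change on two cores in this assay, a 3.1-fold lower number (0.49 log units; beyond the scatter) from compound 2 to compound 3 and a 3.1-fold lower number (0.49 log units; beyond the scatter) from compound 4 to compound 1, 1.0-fold (0.00 log units) apart, within the scatter of two such steps.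

The compounds shown leave open how an amine or a carboxylic acid in place of the nitro would read, and whether the double bond drawn E would give the same numbers.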